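The source may report more compounds than this note shows. Statements on the series, on what has been measured and on what is new or still open speak of the compounds shown alone.

Of the compounds shown here, three built on one shared core have been measured in an ADME assay on a cell-free system (plasma, Rattus norvegicus, strain Sprague-Dawley) for metabolic stability, with a stated time of 30 min, tested at 50 mg/mL; a lower number here means that less of the compound is left, a higher number that more of the compound is left. Compound 1 `CCCc1nc(C(C)(C)O)c(C(=O)NCCNCCO)n1Cc1ccc(-c2ccccc2C2=NNNN2)cc1` gives 98.9%, compound 2 `CCCc1nc(C(C)(C)O)c(C(=O)OCCCCCCC(=O)OCC)n1Cc1ccc(-c2ccccc2C2=NNNN2)cc1` gives 81.1%, and compound 3 `CCCc1nc(C(C)(C)O)c(C(=O)OCc2c[nH]c(=O)[nH]c2=O)n1Cc1ccc(-c2ccccc2C2=NNNN2)cc1` gives 96.3%. Compound 3 thus stands second highest of the three: its gap to compound 1 is within the scatter, while the step of a number 15.2 percentage points higher from compound 2 to compound 3 (beyond the scatter) lies beyond it. Compound 4 `CCCc1nc(C(C)(C)O)c(C(=O)OCCCCCCC(=O)O)n1Cc1ccc(-c2ccccc2C2=NNNN2)cc1` differs from compound 3 by a group of 8 heavy atoms (6 carbon, 2 oxygen; no ring) in place of a group of 8 heavy atoms (4 carbon, 2 nitrogen, 2 oxygen; one six-membered aromatic ring with 2 hetero atoms), on a saturated chain carbon bound to an oxygen next to a carbonyl group. The step of a number 15.2 percentage points higher from compound 2 to compound 3 (beyond the scatter) bears on this change; compound 4 carries a chain resembling that of compound 2. The step of a number 17.8 percentage points lower from compound 1 to compound 2 (beyond the scatter) likewise shows a loss when such a chain enters. A modest drop is therefore expected, about a number 11.3 percentage points lower from compound 3 to compound 4 (beyond the scatter). Compound 4 is estimated at 85% in this assay, with a range from 70% to 96%.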

Compound 4, percent of the compound remaining: 98.8%
Compound 4: the middle estimate sits 13.8 percentage points below what was measured; measured number above the stated range.
By their numbers in this assay, from the lowest: compound 2; then compounds 3, 4 and 1 (each within the scatter of the next).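

In this assay, 5-carboxypentyl at this place, on a saturated chain carbon bound to an oxygen next to a carbonyl group, stands level with the ring-bearing group it replaces, the step being a number 2.5 percentage points higher from compound 3 to compound 4 (within the scatter). The amide side chain of compound 1 is matched as well, with a number 0.1 percentage points lower from compound 1 to compound 4 (within the scatter). An open chain alone therefore does not set compound 2 apart, since replacing only its ethyl by hydrogen gives a number 17.7 percentage points higher from compound 2 to compound 4 (beyond the scatter), and nothing shown explains this difference. From the compounds shown here alone, it remains open whether a longer chain ending in a carboxylic acid, or a chain ending in an amine, would stay level with compound 4.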